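This account rests on a few compounds, and the source may have more. Where it says the series, first, only, none or still open, it means among the compounds named here.

Measured compounds in a functional assay on K562 cells (Homo sapiens) for cytotoxicity, read by MTT assay, with a stated time of 72 h; on this read-out higher numbers stand for weaker inhibition and lower numbers for stronger inhibition:
- Compound 1 `NN1C(=O)/C(=C/c2c[nH]c3ccccc23)SC1=S` gives 22500 nM.
- Compound 2 `O=C1NC(=S)S/C1=C\c1c[nH]c2ccccc12` gives > 50000 nM, which is a limit of this assay and not a number.
- Compound 3 `O=C1NC(=O)/C(=C/c2c[nH]c3ccccc23)S1` gives > 50000 nM, again a limit of this assay.

Among these three, compound 1 is the only compound with an actual number; the other two sit at the limit of > 50000 nM in this assay, at which 2 of the 3 values shown sit. Going by the values given here, the one measured step that connects two of them is an at least 2.2-fold higher number from compound 1 to compound 2 (0.34 log units; beyond the scatter), where the change is hydrogen in place of amino on an amide-type nitrogen in a ring.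

Compound 4 `NN1C(=O)/C(=C/c2c[nH]c3ccc(Br)cc23)SC1=S` keeps the core of compound 1 unchanged and differs only by bromo in place of hydrogen on an aromatic carbon. Among the compounds with values here, none of the measured steps touches this part of the molecule: the only measured step concerns the ring nitrogen, not the aromatic ring, so no measured comparison bears directly on the change from compound 1 to compound 4. Without such evidence, the expectation for compound 4 is a number close to that of compound 1, with no step beyond the scatter, so that a 1.3-fold lower number from compound 1 to compound 4 (0.10 log units; within the scatter) is expected to be small. Compound 4 is therefore estimated at 18000 nM, with a range from 6000 nM to 50000 nM.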

Compound 4, half-maximal inhibitory concentration: > 50000 nM
Compound 4: no number, only a limit; the forecaster's own chance of this, stated with the estimate: 25%; at least 2.7-fold (0.44 log units) between middle value and limit.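

In this assay, compound 4 gives > 50000 nM, which is a limit of this assay and not a number. Going by these compounds alone, the earlier compounds showed only that the amino group on the ring nitrogen mattered, whereas this result is the first evidence that the aromatic part of the molecule matters too: bromo in place of hydrogen on this aromatic carbon gives an at least 2.2-fold higher number from compound 1 to compound 4 (0.34 log units; beyond the scatter), beyond the scatter, even though the amino group stays in place. So the measurable activity of compound 1 depends on both ends of the molecule, but only the lower bound of this loss can be read, and the true size of the step stays unknown: the limit of > 50000 nM in this assay, at which 3 of the 4 values shown sit.

From the compounds shown here alone, it remains open whether a smaller group on the same carbon, such as fluoro or methyl, or a group of another kind, such as methoxy or a carboxylic acid, would keep a measurable number in this assay. Going by these compounds, it is also open whether bromo on a different carbon of the same six-membered ring would have the same effect, so nothing yet shows how far this result extends beyond this one position and this one group.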